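One Added Chloro Group on Two Related Cores

The source may hold more compounds than are shown below. What is called first, only, known or untested is meant among the compounds shown, and "the series" means these compounds.

Compound 1 `CCCCCC(CCO)n1cnc2c(Cl)ncnc21` and compound 2 `CCCCCC(CCO)n1cnc2c(Cl)nc(Cl)nc21` share one core and differ in a single group. In a functional assay on SW480 cells (Homo sapiens) for antiproliferative activity, read by MTT assay, with a stated time of 48 h (on this read-out higher numbers stand for weaker inhibition and lower numbers for stronger inhibition), compound 1 gives only a limit of the assay, > 50000 nM. In this assay compound 2 gives 6010 nM. The change chloro in place of hydrogen on an aromatic carbon therefore brought an at least 8.3-fold lower number from compound 1 to compound 2 (0.92 log units; beyond the scatter), a step whose size rests on (the limit of > 50000 nM in this assay, at which 2 of the 3 values shown sit). Compound 3 `CCCCCCC(CCO)n1cnc2c(N)ncnc21` carries a different core; the difference between the two cores is not broken down here. In this assay compound 3 gives only a limit of the assay, > 50000 nM. Compound 4 `CCCCCCC(CCO)n1cnc2c(N)nc(Cl)nc21` is not yet measured and differs from compound 3 by chloro in place of hydrogen on an aromatic carbon, the same kind of change, though here the place is meta to an amino group rather than meta to a chloro group. Compound 4 is expected to show an at least 2.5-fold lower number from compound 3 to compound 4 (0.39 log units; beyond the scatter). That expectation rests on an at least 8.3-fold lower number from compound 1 to compound 2 (0.92 log units; beyond the scatter), while the amino group leaves the outcome uncertain. Compound 4 is estimated at 20000 nM, between 5000 nM and 50000 nM.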

Compound 4, half-maximal inhibitory concentration: > 50000 nM
Compound 4: only a limit was reported; the forecaster's own chance of this, stated with the estimate: 40%; at least 2.5-fold (0.39 log units) between middle value and limit.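

Compound 3 and compound 4 both stop at a limit in this assay, so no step can be read between them: the limit of > 50000 nM in this assay, at which 3 of the 4 values shown sit.

Going by these compounds, whether the added chloro changes anything on the core of compound 3 stays open.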